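Working notes: removing one methoxy from compound 1

The source may hold more compounds than are shown below. What is called first, only, known or untested is meant among the compounds shown, and "the series" means these compounds.

Measured so far:
compound 1 `COc1cc(/C=N/c2c(C#N)ncn2-c2ccc(F)cc2)cc(OC)c1OC` gives 13700 nM
compound 2 `N#Cc1ncn(-c2ccc(F)cc2)c1/N=C/c1ccc([N+](=O)[O-])cc1` gives 15900 nM
compound 3 `N#Cc1ncn(-c2ccc(F)cc2)c1/N=C/c1cc([N+](=O)[O-])ccc1O` gives 15300 nM

All three compounds were read in a functional assay on HT-29 cells (Homo sapiens) for antiproliferative activity, read by MTT assay, with a stated time of 48 h (on this read-out lower numbers stand for stronger inhibition and higher numbers for weaker inhibition), and lie within the scatter of one another. On these numbers, compound 1 at 13700 nM cannot be separated from the other two.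

Compound 4 `COc1ccc(/C=N/c2c(C#N)ncn2-c2ccc(F)cc2)cc1OC` has not yet been measured. The structural change from compound 1 to compound 4 reads hydrogen in place of methoxy on an aromatic carbon and amounts to hydrogen in place of methoxy on an aromatic carbon.

Within the data shown here, no measured pair differs in one place only, so this step has no direct precedent. The closest guide is that compound 2 at 15900 nM and compound 3 at 15300 nM stay within the scatter of compound 1 despite differing from it in several places. Three compounds are a thin basis, but a step beyond the scatter in this assay is not expected, and no direction is favoured. The estimated step is a 1.1-fold higher number from compound 1 to compound 4 (0.04 log units; within the scatter) and would stay within the scatter. Compound 4 is expected at 15000 nM with an estimated range of 7500 nM to 30000 nM in this read-out.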

Compound 4, half-maximal inhibitory concentration: 7230 nM
Beside the measured number, compound 4's estimate is 2.1-fold (0.32 log units) above it; the measured number lies below the stated range.
By their numbers in this assay, from the lowest: compounds 4, 1, 3 and 2 (each within the scatter of the next, the first and the last beyond it).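

In this assay, the series now holds its first pair that differs in one place only, and it reads a 1.9-fold lower number from compound 1 to compound 4 (0.28 log units; within the scatter) for hydrogen in place of methoxy on an aromatic carbon. This position lies ortho to a methoxy group, meta to a large group and meta to a methoxy group, and the step shows that losing the methoxy there, with its 2 heavy atoms and 1 hydrogen-bond acceptor, does not move the read-out beyond the scatter, so this assay gives no sign that the group is needed at this position. No measurement at hand speaks to what lies behind the size of this step.

Still open, from the compounds shown here alone, is whether a different group at this position, such as an amine, a carboxylic acid or a longer alkoxy chain, would give a step beyond the scatter from compound 4. Also open, going by these compounds, is whether replacing either of the two methoxy groups that remain on compound 4 with hydrogen would stay within the scatter in the same way.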